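One Methyl, Two Places: Estimating Compound 4

The source may hold more compounds than are shown below. What is called first, only, known or untested is meant among the compounds shown, and "the series" means these compounds.

In a functional assay on MCF7 cells (Homo sapiens) for cytotoxicity, read by MTT assay, with a stated time of 72 h (on this read-out lower numbers stand for stronger inhibition and higher numbers for weaker inhibition), the three measured compounds gave these values:
Compound 1 `N/C(=N\NC(=S)N1CCCCCC1)c1ccccn1`: 2600 nM
Compound 2 `Cc1ccnc(/C(N)=N/NC(=S)N2CCSCC2)c1`: 6900 nM
Compound 3 `N/C(=N\NC(=S)N1CCSCC1)c1ccccn1`: 8800 nM

Compound 1 gives the lowest of the three numbers, and its steps to both others lie beyond the scatter. Compound 2 and compound 3 share one core, compound 1 another; how the two cores differ is not broken down here. From compound 3 to compound 2 the change is methyl in place of hydrogen on an aromatic carbon, and it made a 1.3-fold lower number from compound 3 to compound 2 (0.11 log units; within the scatter). Compound 4 `Cc1cccc(/C(N)=N/NC(=S)N2CCCCCC2)n1` arises from compound 1 by methyl in place of hydrogen on an aromatic carbon. This is the same kind of change, but not the same: in compound 4 the methyl is next to the ring nitrogen, whereas in compound 2 it is opposite the ring nitrogen. Because the step of a 1.3-fold lower number from compound 3 to compound 2 (0.11 log units; within the scatter) lay within the scatter, the step expected for compound 4 is a 1.1-fold lower number from compound 1 to compound 4 (0.05 log units; within the scatter). Compound 4 is therefore estimated at 2300 nM, expected to lie between 1100 nM and 5000 nM in this assay.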

Compound 4, half-maximal inhibitory concentration: 54700 nM
For compound 4 the middle estimate is 24-fold (1.38 log units) below the measured one; measured number above the stated range.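

In this assay, methyl in place of hydrogen on an aromatic carbon gave a 21-fold higher number from compound 1 to compound 4 (1.32 log units; beyond the scatter), so this change cannot be carried from one core to the other in this series as a single step: the same change on two cores in this assay, a 1.3-fold lower number (0.11 log units; within the scatter) from compound 3 to compound 2 and a 21-fold higher number (1.32 log units; beyond the scatter) from compound 1 to compound 4, 27-fold (1.43 log units) apart, beyond the scatter of two such steps

The two steps differ in more than the core, since the methyl stands next to the ring nitrogen in compound 4 and elsewhere on the ring in compound 2. The compounds shown therefore do not tell whether the core, the place of the methyl or both separate the two steps.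

From the compounds shown here alone, it remains open what a methyl next to the ring nitrogen would do on the core of compound 3. Also open, going by these compounds, is how an ethyl or a methoxy group would behave at that place on either core.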